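Hydrogen Replaces 4-Chlorophenyl on the Ring Amide Nitrogen

The source may hold more compounds than are shown below. What is called first, only, known or untested is meant among the compounds shown, and "the series" means these compounds.

Compound 1 `O=C1COc2ccc(-c3cnc(Cl)c(NS(=O)(=O)c4ccc(F)cc4)c3)cc2N1c1ccccc1` and compound 2 `O=C1COc2ccc(-c3cccc(NS(=O)(=O)c4ccc(F)cc4)c3)cc2N1c1ccc(Cl)cc1` share the same core and the same sulfonamide. In a functional assay on HepG2 cells (Homo sapiens) for antiproliferative activity, read by MTT assay, with a stated time of 72 h (a higher number here means a weaker inhibitor, a lower number a stronger inhibitor), compound 1 gives 35700 nM, and in this assay compound 2 gives 27800 nM; the two numbers lie within the scatter of each other, so neither stands apart. Compound 3 `O=C1COc2ccc(-c3cccc(NS(=O)(=O)c4ccc(F)cc4)c3)cc2N1` differs from compound 2 by hydrogen in place of 4-chlorophenyl on an amide-type nitrogen in a ring. Among the measured compounds shown here, no measured pair shows the effect of this change. Compound 3 is expected to remain close, with a modest step of a 1.5-fold higher number from compound 2 to compound 3 (0.18 log units; within the scatter) in this assay toward a weaker inhibitor, possibly not beyond the scatter. Compound 3 is estimated at 42000 nM, within 15000 nM to 120000 nM.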

Compound 3, half-maximal inhibitory concentration: > 40000 nM
Compound 3: no number, only a limit (the forecaster's own chance of this, stated with the estimate: 20%); the middle value does not contradict the limit.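

In this assay compound 3 gives only a limit, not a number: the limit of > 40000 nM in this assay, at which 1 of the 3 values shown sits. Among the compounds shown here, replacing 4-chlorophenyl with hydrogen on the amide-type nitrogen in the ring gives the first direct reading at this position, an at least 1.4-fold higher number from compound 2 to compound 3 (0.15 log units; that floor lies within the scatter), and it shows no move toward a stronger inhibitor. Since this is only a floor, the true size of the step cannot be read, and the change may or may not exceed the scatter.

The compounds shown leave open how a small alkyl group such as methyl, or a chain ending in an amine or a carboxylic acid, would behave on this nitrogen.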